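The source may report more compounds than this note shows. Statements on the series, on what has been measured and on what is new or still open speak of the compounds shown alone.

Series notes. Compound 1 `Nc1sc(-c2ccccc2)c(-c2ccccc2)c1C(=O)c1ccc(Cl)cc1` is taken as the starting point. In an assay on CHO cells for displacement of a labelled ligand from adenosine receptor A1 (Homo sapiens), read by scintillation counting, tested at 10 uM (on this read-out lower numbers stand for less inhibition and higher numbers for more inhibition at the one concentration tested (going by the name of the read-out)), compound 1 gives 1%. Two further members carry a neopentyl group on the shared core: compound 2 `CC(C)(C)Cc1c(-c2cccnc2)sc(N)c1C(=O)c1ccc(Cl)cc1`, which in this assay gives 1%, and compound 3 `CC(C)(C)Cc1c(-c2cccc(F)c2F)sc(N)c1C(=O)c1ccc(Cl)cc1`, which in this assay gives 1%. For the measured compounds named here, the one step that can be read between measured compounds, no change at the digits printed from compound 2 to compound 3 (within the scatter), shows that exchanging the aromatic group on the neopentyl-bearing core leaves the read-out where it was. Compound 1 stands level with compounds 2 and 3 at the digits shown; all three sit at the same low value within the scatter.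

Compound 4 `CC(C)(C)Cc1c(-c2ccccc2)sc(N)c1C(=O)c1ccc(Cl)cc1` differs from compound 1 as follows: neopentyl in place of phenyl on an aromatic carbon. Going by the values given here, no measured step reproduces this exact change. Compounds 2 and 3, which already carry neopentyl together with other aromatic groups, sit at the same low level as compound 1, so nothing in the measured data points to movement in either direction. The expected step is therefore a number 1 percentage points higher from compound 1 to compound 4 (within the scatter), within the scatter. For compound 4 the estimated value in this assay is 2%, with a range from 0% to 12%.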

Compound 4, a percentage reported as inhibition, at one concentration (the size of the read-out at that concentration, not a potency): 1%
For compound 4 the middle estimate is 1 percentage points above the measured one; the range from low to high includes it.
By their numbers in this assay, from the lowest: compounds 1, 2, 3 and 4 (each within the scatter of the next).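

For the compounds shown here, compound 4 gives the first direct reading of this position in this assay: no change at the digits printed from compound 1 to compound 4 (within the scatter), so neopentyl and phenyl on this aromatic carbon cannot be told apart on this read-out. With neopentyl held in place, the aromatic group gives the same picture, with no change at the digits printed from compound 3 to compound 4 (within the scatter) for phenyl in place of 2,3-difluorophenyl and no change at the digits printed from compound 2 to compound 4 (within the scatter) for phenyl in place of pyridin-3-yl. No supporting data bear on why the read-out stays flat across these exchanges.

From the compounds shown here alone, whether a basic amine, a carboxylic acid or a chain longer than neopentyl at this position would shift the read-out remains open. Also open, going by these compounds, is whether any change to the amino group or the (4-chlorophenyl)carbonyl group would do so.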